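Anilide series: imidazolyl replaced by ethoxyethylamino substituent

The source may hold more compounds than are shown below. What is called first, only, known or untested is meant among the compounds shown, and "the series" means these compounds.

Measured so far:
compound 1 `CNCCN(C)c1cccc(NC(=O)CN2N=C(C3CCCCC3)c3ccccc3N(CC(=O)C(C)(C)C)C2=O)c1` 117 nM
compound 2 `CC(C)(C)C(=O)CN1C(=O)N(CC(=O)Nc2cccc(-n3ccnc3)c2)N=C(C2CCCCC2)c2ccccc21` 871 nM

In a functional assay on stomach for binding affinity to Gastrin/cholecystokinin type B receptor (Rattus norvegicus) (a higher number here means weaker binding, a lower number tighter binding), compound 2 gives the highest of the two numbers; its nearest neighbour is compound 1, and a 7.4-fold higher number from compound 1 to compound 2 (0.87 log units; beyond the scatter) separates them. Compound 3 `CCOCCNc1cccc(NC(=O)CN2N=C(C3CCCCC3)c3ccccc3N(CC(=O)C(C)(C)C)C2=O)c1` differs from compound 2 in one place: (2-ethoxyethyl)amino in place of 1H-imidazol-1-yl on an aromatic carbon. Going by the values given here, the only step that bears on this is a 7.4-fold higher number from compound 1 to compound 2 (0.87 log units; beyond the scatter), where an amino substituent gave way to the imidazolyl; compound 3 again carries an amino substituent, though not the same one. A lowering step is therefore expected, smaller than that earlier step: compound 3 is estimated at 280 nM (range 90 nM to 850 nM), a change of a 3.1-fold lower number from compound 2 to compound 3 (0.49 log units; beyond the scatter) in this assay.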

Compound 3, dissociation constant: 105 nM
Compound 3: middle estimate off by 2.7-fold (0.43 log units), on the high side, and the stated range covers the measured number.
By their numbers in this assay, from the lowest: compounds 3 and 1 (each within the scatter of the next); then compound 2.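

In this assay, the loss seen with 1H-imidazol-1-yl is not a general feature of this position, since (2-ethoxyethyl)amino restores binding (an 8.3-fold lower number from compound 2 to compound 3 (0.92 log units; beyond the scatter)). The methylamino chain end of compound 1 is not required for this level, as the two amino substituents cannot be told apart (a 1.1-fold lower number from compound 1 to compound 3 (0.05 log units; within the scatter)). No measurement here accounts for the difference from the imidazolyl group.

From the compounds shown here alone, whether a short dimethylamino group or a chain ending in a carboxylic acid would hold this level stays open. So does any role of the ether oxygen, which an all-carbon pentylamino chain would test.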